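Swapping one group on the shared core: compound 3

The source may report more compounds than this note shows. Statements on the series, on what has been measured and on what is new or still open speak of the compounds shown alone.

Compound 1 `Cc1ccc(F)c(Nc2ncnc3cc(NC(=O)CCCCCCC(=O)NO)sc23)c1`: 1330 nM
Compound 2 `N#Cc1cccc(Nc2ncnc3cc(NC(=O)CCCCCCC(=O)NO)sc23)c1`: 2090 nM

Both numbers come from a functional assay on HCT-116 cells (Homo sapiens) for antiproliferative activity, read by radiometric assay, with a stated time of 72 h; on this read-out higher numbers stand for weaker inhibition and lower numbers for stronger inhibition. For the measured compounds named here, compound 2 stands level with compound 1, its only measured neighbour. Going by the values given here, the single measured step is a 1.6-fold higher number from compound 1 to compound 2 (0.20 log units; within the scatter). Putting 3-cyanophenyl in place of 2-fluoro-5-methylphenyl on a nitrogen on an aromatic ring therefore gave two numbers that cannot be told apart.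

Compound 3 `COc1ccc(Nc2ncnc3cc(NC(=O)CCCCCCC(=O)NO)sc23)cc1` keeps the shared core and carries 4-methoxyphenyl in place of 3-cyanophenyl at that same place: 4-methoxyphenyl in place of 3-cyanophenyl on a nitrogen on an aromatic ring. Neither measured compound carries 4-methoxyphenyl, so the data give no direction. Among the compounds with values here, the one step available stayed within the scatter, so no step beyond the scatter is expected in this assay. The expected step is a 1.2-fold lower number from compound 2 to compound 3 (0.09 log units; within the scatter). For compound 3 the estimated value is 1700 nM, with an expected range from 600 nM to 4500 nM.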

Compound 3, half-maximal inhibitory concentration: 2180 nM
Compound 3: the middle estimate sits 1.3-fold (0.11 log units) below what was measured, within the range that was stated.
By their numbers in this assay, from the lowest: compounds 1, 2 and 3 (each within the scatter of the next).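

Putting 4-methoxyphenyl in place of 3-cyanophenyl on this nitrogen gives little in this assay (a 1.0-fold higher number from compound 2 to compound 3 (0.02 log units; within the scatter)), and putting it in place of 2-fluoro-5-methylphenyl gives no more (a 1.6-fold higher number from compound 1 to compound 3 (0.21 log units; within the scatter)). All three groups, one with a nitrile, one with a methoxy and one with a fluorine and a methyl, therefore give numbers that cannot be told apart in this assay, so among these compounds the read-out does not separate the groups at this place. Nothing measured here offers an explanation for this result.

On these data alone, all three compounds carry a substituted phenyl on this nitrogen, so it remains open whether a small alkyl group such as methyl, or a phenyl bearing an amine or a carboxylic acid, would stay within the same scatter. As far as these compounds go, it is also open whether a longer chain in place of the one on the shared core would shift the numbers more than these changes do.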